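The source may hold more compounds than are shown below. What is called first, only, known or untested is meant among the compounds shown, and "the series" means these compounds.

Compound 2 `O=C(/C(=C\c1c[nH]c2ccccc12)Sc1ccc(Br)cc1)c1ccc(Br)cc1` gives the lowest number of the three measured compounds in a functional assay on DU-145 cells (Homo sapiens) for inhibition, read by trypan blue exclusion, with a stated time of 96 h (on this read-out higher numbers stand for weaker inhibition of growth and lower numbers for stronger inhibition of growth), with a value of 1000 nM. Compound 1 `Cc1ccc(S/C(=C/c2c[nH]c3ccccc23)C(=O)c2ccc(Br)cc2)cc1` gives 10000 nM in this assay, and compound 3 `O=C(/C(=C\c1c[nH]c2ccccc12)S(=O)(=O)c1ccc(Br)cc1)c1ccc(Br)cc1` gives 25000 nM. The steps of a 10-fold lower number from compound 1 to compound 2 (1.00 log units; beyond the scatter) and a 25-fold higher number from compound 2 to compound 3 (1.40 log units; beyond the scatter) are both beyond the scatter, as is a 2.5-fold higher number from compound 1 to compound 3 (0.40 log units; beyond the scatter); all three concern the aryl group hanging from sulfur. Compound 4 `O=C(/C(=C\c1ccc(Cl)cc1)Sc1ccc(Br)cc1)c1ccc(Br)cc1` differs from compound 2 at a different place on the shared core: 4-chlorophenyl in place of 1H-indol-3-yl on a double-bonded chain carbon bound to a double-bonded chain carbon. For the measured compounds named here, none of the measured steps touches this position, so they offer no direct guide; they show only that single changes elsewhere on this core can move the number by a large amount in either direction. The entering group is smaller and carries no hydrogen-bond donor, whereas the leaving group carries one. Compound 4 is therefore expected to give a somewhat higher number, around 3000 nM, with a range from 600 nM to 15000 nM. This estimate corresponds to an expected step of a 3.0-fold higher number from compound 2 to compound 4 (0.48 log units; beyond the scatter).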

Compound 4, concentration for 50% growth inhibition: 1000 nM
Estimate against measurement, compound 4: 3.0-fold (0.48 log units) above, and the stated range covers the measured number.
By their numbers in this assay, from the lowest: compounds 2 and 4 (each within the scatter of the next); then compound 1; then compound 3.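

In this assay, putting 4-chlorophenyl in place of 1H-indol-3-yl gives no change at the digits printed from compound 2 to compound 4 (within the scatter). For this pair, neither the five-membered ring nor the hydrogen-bond donor of the leaving group is needed to hold the number at this level, so this carbon accepts a clear change of group without a measurable shift. The change at sulfur from compound 2 to compound 3 gave a 25-fold higher number from compound 2 to compound 3 (1.40 log units; beyond the scatter), so a large structural change does not always move the number on this core, and the data give no reason why the two groups read alike here.

As far as these compounds go, it remains open whether the chlorine contributes anything, which a plain phenyl group could test, and whether a group carrying an amine or a carboxylic acid would also be accepted at this carbon. The compounds shown also cannot tell whether 4-chlorophenyl behaves the same way when the sulfur carries 4-methylphenyl or is part of a sulfonyl group.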